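A few compounds are considered here, and "the series" means these few. Any claim that something is new, unique, unknown or untested is made for them only; others in the source may bear on it.

Measured compounds:
compound 1 `COC(=O)C[C@H](NC(=O)OC(C)(C)C)C(=O)N(Cc1ccc(F)cc1)C1(C(=O)NCc2ccccc2)CCN(C)CC1` gives 17000 nM in an ADME assay on MDCK cells (Canis lupus familiaris) for cytotoxicity, read by microscopy, with a stated time of 72 h; a lower number here means that less compound is tolerated, a higher number that more compound is tolerated;
compound 2 `COC(=O)C[C@H](NC(=O)OC(C)(C)C)C(=O)N(Cc1ccc(F)cc1)C1(C(=O)NCc2ccccc2)CCN(c2ccccc2)CC1` gives 20000 nM in this assay.

Compound 2 stands at the higher of the two numbers, but only narrowly: the step of a 1.2-fold higher number from compound 1 to compound 2 (0.07 log units; within the scatter) lies within the scatter, so the two compounds cannot be told apart on this assay.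

Compound 3 `COC(=O)C[C@H](NC(=O)OC(C)(C)C)C(=O)N(Cc1ccc(F)cc1)C1(C(=O)NCc2ccccc2)CCN(Cc2cccc(F)c2)CC1` has not yet been measured. It differs from compound 2 in one place: 3-fluorobenzyl in place of phenyl on an amine nitrogen in a ring. Among the measured compounds shown here, the one measured step that bears on this change is the one from compound 1 to compound 2, a 1.2-fold higher number from compound 1 to compound 2 (0.07 log units; within the scatter), which also swapped the group on the amine nitrogen in a ring and produced no movement beyond the scatter. With nothing else to go on, a further swap of the group at that nitrogen is expected to leave the tolerated concentration of compound 3 close to that of compound 2, with a step of about no change at the digits printed from compound 2 to compound 3 (within the scatter) expected. The estimate for compound 3 in this assay is therefore 20000 nM, with a range from 9000 nM to 45000 nM.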

Compound 3, minimum cytotoxic concentration: 84000 nM
Estimate against measurement, compound 3: 4.2-fold (0.62 log units) below; measured number outside the range, above it.
By their numbers in this assay, from the lowest: compounds 1 and 2 (each within the scatter of the next); then compound 3.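

In this assay, the group on the amine nitrogen in a ring proves able to move the tolerated concentration: 3-fluorobenzyl in place of phenyl gives a 4.2-fold higher number from compound 2 to compound 3 (0.62 log units; beyond the scatter), and the same group measured against methyl gives a 4.9-fold higher number from compound 1 to compound 3 (0.69 log units; beyond the scatter). Both steps lie beyond the scatter and run in the same direction, whereas the earlier swap between methyl and phenyl at this nitrogen had shown no movement beyond it, so that swap did not speak for every group at this position. No measurement shown here accounts for the rise at compound 3.

Going by these compounds, it remains open whether the rise goes with the fluorine, with the saturated carbon that joins the aromatic ring to the nitrogen, or with both together, and a plain benzyl group at this nitrogen would separate these possibilities. On these data alone, it is also open whether the higher number would hold with a 4-fluorobenzyl group or with a longer chain such as phenylethyl.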